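The compounds below may be only part of what the source reports. "The series", "measured", "known", "first", "only" and "open" are said of these compounds alone.

Going by the values given here, in a functional assay, with a stated time of 20 min (on this read-out higher numbers stand for an effect only at larger amounts of compound and lower numbers for an effect already at smaller amounts), only two compounds carry numbers so far. Compound 1 `O=c1cc(-c2cc(O)c(O)c(O)c2)oc2ccccc12` gives 0.33 ug/mL and holds the lower of the two numbers. Compound 2 `COc1cc(-c2oc3ccccc3c(=O)c2F)cc(OC)c1OC` gives 37.1 ug/mL and lies beyond the scatter from compound 1 on the higher side. Compound 3 `O=c1c(F)c(-c2cc(O)c(O)c(O)c2)oc2ccccc12` is still unmeasured. One change separates it from compound 1: fluoro in place of hydrogen on an aromatic carbon. Among the compounds with values here, no measured pair differs in one place only, so the data give no direct size for this change. With nothing to point either way, no step beyond the scatter is expected in this assay and no firm direction is assumed. The expected outcome is a 1.2-fold higher number from compound 1 to compound 3 (0.08 log units; within the scatter) as a working figure only. Compound 3 is estimated at 0.4 ug/mL with a range from 0.13 ug/mL to 1.5 ug/mL as the expected span.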

Compound 3, half-maximal effective concentration: 0.24 ug/mL
The estimate for compound 3 lay 1.7-fold (0.22 log units) above the measured number, within the range that was stated.
By their numbers in this assay, from the lowest: compounds 3 and 1 (each within the scatter of the next); then compound 2.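

Fluoro in place of hydrogen on this aromatic carbon, two atoms from the ring oxygen, gives in this assay a 1.4-fold lower number from compound 1 to compound 3 (0.14 log units; within the scatter) and so stays within the scatter. Going by these compounds alone, the earlier compounds held no pair differing in one place, so this is the first direct size for the change, and it shows that this position of the core of compound 1 accepts a fluoro group with no step beyond the scatter. No measurement at hand speaks to a reason for this outcome.

Open, from the compounds shown here alone, is whether a chloro, methyl or amino group on the same carbon would also stay within the scatter. Also open, going by these compounds, is the size of the same change on the core of compound 2, where a partner carrying hydrogen on that carbon would be needed.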